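Notes on the step from compound 2 to compound 4

The source may hold more compounds than are shown below. What is called first, only, known or untested is meant among the compounds shown, and "the series" means these compounds.

Measured in an in vitro ADME assay on microsomes from liver (Rattus norvegicus) for metabolic stability; on this read-out lower numbers stand for slow clearance and higher numbers for fast clearance:
Compound 1 (`Cc1ccc(Cn2c(=O)[nH]c3c(N)nc(-c4ncco4)cc32)cn1`) gives < 8.5 mL.min-1.g-1 (a limit)
Compound 2 (`Cc1ccc(Cn2c(=O)[nH]c3c(N)nc(C(F)(F)F)cc32)cn1`) gives < 8.5 mL.min-1.g-1 (a limit)
Compound 3 (`Cc1cccc(Cn2c(=O)[nH]c3c(N)nc(C(F)(F)F)cc32)n1`) gives 27 mL.min-1.g-1 (a number)

On these data alone, compound 2 gives only a limit and no number, so it stands at the limit of < 8.5 mL.min-1.g-1 in this assay, at which 2 of the 3 values shown sit, and the true start of the step is unknown.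

Compound 4 (`Nc1nc(C(F)(F)F)cc2c1[nH]c(=O)n2Cc1ccc(NCC2CC2)nc1`) carries (cyclopropylmethyl)amino in place of methyl on an aromatic carbon, next to the ring nitrogen and para to a large group ((cyclopropylmethyl)amino in place of methyl on an aromatic carbon).

Neither measured step makes this replacement. One is a step that the two limits leave unreadable from compound 1 to compound 2 and gives no size to work from. Going by the values given here, the other is an at least 3.1-fold higher number from compound 2 to compound 3 (0.50 log units; beyond the scatter) and is the only readable guide, since it also alters the methyl-bearing group of compound 2. Compound 3 gives 27 mL.min-1.g-1 and shows that a change in that group can raise the read-out in this series.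

On that single precedent, a rise of similar modest size is expected rather than no change. The expected change is an at least 2.0-fold higher number from compound 2 to compound 4 (0.30 log units; that floor lies within the scatter) and its estimated direction is upward. In this assay compound 4 is estimated at 17 mL.min-1.g-1 (expected range 8 mL.min-1.g-1 to 40 mL.min-1.g-1) and it may still return only a limit.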

Compound 4, intrinsic clearance in microsomes: 85 mL.min-1.g-1
The estimate for compound 4 lay 5.0-fold (0.70 log units) below the measured number, and the stated range ends below it.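

In this assay, the methyl on an aromatic carbon of the six-membered aromatic ring with 1 nitrogen, next to the ring nitrogen and para to a large group, proves open to a change that moves the read-out strongly: (cyclopropylmethyl)amino in its place gives an at least 10-fold higher number from compound 2 to compound 4 (1.00 log units; beyond the scatter). The earlier readable step swapped 6-methylpyridin-3-yl for 6-methylpyridin-2-yl, whereas this one keeps the attachment of the ring and alters only the group at this position, so the group at this position alone is enough to carry the series to fast clearance. Compound 2 gives only a limit, so the size of the step is a floor and the true start remains unknown: the limit of < 8.5 mL.min-1.g-1 in this assay, at which 2 of the 4 values shown sit.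

The compounds shown leave open which part of the (cyclopropylmethyl)amino group goes with the rise, since a primary amine, a dimethylamino group or a cyclopropyl group bound directly to this carbon would separate the nitrogen from the carbon chain and its ring. Also open, on these data alone, is whether the same replacement has a like effect when 1,3-oxazol-2-yl stands in place of trifluoromethyl, as in compound 1.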